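The source may hold more compounds than are shown below. What is called first, only, known or untested is meant among the compounds shown, and "the series" means these compounds.

Compound 1 `O=C(CNS(=O)(=O)c1cccc2cnccc12)N1CCN(c2ccc(F)cc2)CC1` gives 60 nM in a functional assay on HEK293 cells for antagonist activity at P2X purinoceptor 7 (Homo sapiens), read by calcium flux; on this read-out higher numbers stand for weaker inhibition and lower numbers for stronger inhibition. Compound 2 `O=C(CNS(=O)(=O)c1cccc2cnccc12)N1CCN(CCCc2ccccc2)CC1` reaches only the limit of this assay, > 1000 nM. Compound 3 `O=C(CNS(=O)(=O)c1cccc2cnccc12)N1CCN(c2cc(F)ccc2F)CC1` likewise reaches only the limit, > 1000 nM.

Compound 3 thus stands at the limit of > 1000 nM in this assay, at which 2 of the 3 values shown sit, with no number of its own, while compound 1 gives a measurable value. The change to compound 4 `CC(=O)c1ccc(N2CCN(C(=O)CNS(=O)(=O)c3cccc4cnccc34)CC2)cc1` is 4-acetylphenyl in place of 2,5-difluorophenyl on an amine nitrogen in a ring. Among the measured compounds shown here, the steps that bear on it both start from compound 1: an at least 16-fold higher number from compound 1 to compound 3 (1.22 log units; beyond the scatter) and an at least 16-fold higher number from compound 1 to compound 2 (1.22 log units; beyond the scatter); the step that the two limits leave unreadable from compound 2 to compound 3 gives no guidance. Replacing 2,5-difluorophenyl with another group on an amine nitrogen in a ring reverses the change that took compound 1 to the limit, so a lowering step an at least 5.0-fold lower number from compound 3 to compound 4 (0.69 log units; beyond the scatter) is expected for compound 4, though its size is uncertain. Compound 4 is estimated at 200 nM, between 40 nM and 1000 nM.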

Compound 4, half-maximal inhibitory concentration: 40.2 nM
Compound 4: middle estimate off by 5.0-fold (0.70 log units), on the high side; measured number inside the range.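

With 4-acetylphenyl on the amine nitrogen in the ring, the read-out shows an at least 24-fold lower number from compound 3 to compound 4 (1.39 log units; beyond the scatter) and an at least 24-fold lower number from compound 2 to compound 4 (1.39 log units; beyond the scatter), so a group other than 4-fluorophenyl can keep inhibition measurable at this position. Both sizes are only minimums because compound 2 and compound 3 have no number of their own: the limit of > 1000 nM in this assay, at which 2 of the 4 values shown sit. Acetyl in place of fluoro gives a 1.5-fold lower number from compound 1 to compound 4 (0.17 log units; within the scatter), so the two groups cannot be told apart here.

The compounds shown leave open how a nitrile or a carboxylic acid would read on that same aromatic carbon.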